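Aryl in place of cyclopentyl on the amide-type nitrogen

A few compounds are considered here, and "the series" means these few. Any claim that something is new, unique, unknown or untested is made for them only; others in the source may bear on it.

Measured so far:
compound 1 `O=C(Nc1cccc(CNc2nccnc2Cl)c1)NC1CCCC1` — 18400 nM
compound 2 `O=C(Nc1cccc(CNc2nccnc2Cl)c1)Nc1cccc2ccccc12` — > 40000 nM

Going by the values given here, in a functional assay on HepG2 cells (Homo sapiens) for antiproliferative activity, read by MTT assay, with a stated time of 48 h (a lower number here means a stronger inhibitor, a higher number a weaker inhibitor), compound 1 gives 18400 nM, the only number in the set. Compound 2 reaches only a limit of the assay, (the limit of > 40000 nM in this assay, at which 1 of the 2 values shown sits). Compound 3 `O=C(Nc1cccc(CNc2nccnc2Cl)c1)Nc1ccc(Cl)c(Cl)c1` changes compound 1 by 3,4-dichlorophenyl in place of cyclopentyl on an amide-type nitrogen. Among the compounds with values here, no measured pair differs in one place, so the direction of this change is untested. For compound 3 the step of a 1.2-fold higher number from compound 1 to compound 3 (0.08 log units; within the scatter) is expected to be small, toward weaker inhibition or none beyond the scatter. Compound 3 is estimated at 22000 nM, within 7000 nM to 60000 nM.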

Compound 3, half-maximal inhibitory concentration: 6170 nM
The estimate for compound 3 lay 3.6-fold (0.55 log units) above the measured number; measured number below the stated range.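

In this assay, 3,4-dichlorophenyl in place of cyclopentyl on the amide-type nitrogen gives a 3.0-fold lower number from compound 1 to compound 3 (0.47 log units; beyond the scatter). Going by these compounds alone, this position therefore accepts an aromatic ring without loss, and compound 3 gives the first step here that can be read. The aryl group of compound 2 goes against any general gain from an aryl group, and its value is only a limit: the limit of > 40000 nM in this assay, at which 1 of the 3 values shown sits.

Still open, on these data alone, is whether the gain needs both chlorines, or would survive with a single chlorine or an unsubstituted phenyl. A pyridine ring or an amine on this nitrogen also remains untested in the compounds shown.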